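The source may report more compounds than this note shows. Statements on the series, on what has been measured and on what is new or still open speak of the compounds shown alone.

Of the compounds shown here, three sharing one core have been measured in an ADME assay on CCRF-CEM cells (Homo sapiens) for cytotoxicity, with a stated time of 5 days; on this read-out lower numbers stand for stronger inhibition and higher numbers for weaker inhibition. Compound 1 `CNc1nc(Cl)nc2c1ncn2[C@H]1C[C@H](N=[N+]=[N-])[C@@H](CO)O1` reached only the limit of the method, giving > 100000 nM. Compound 3 `COc1nc(NC2CC2)c2ncn([C@H]3C[C@H](N=[N+]=[N-])[C@@H](CO)O3)c2n1` likewise reached a limit in this assay, > 100000 nM. Among the compounds with values here, compound 2 `[N-]=[N+]=N[C@H]1C[C@H](n2cnc3c(N)nc(F)nc32)O[C@@H]1CO`, the only one reported as a number, gives 30100 nM in this assay. Compound 1 thus stands at the limit of > 100000 nM in this assay, at which 2 of the 3 values shown sit, while compound 2 alone falls inside the range the method can report.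

Compound 4 `COc1nc(Cl)nc2c1ncn2[C@H]1C[C@H](N=[N+]=[N-])[C@@H](CO)O1` has not yet been measured. It differs from compound 1 in one place: methoxy in place of methylamino on an aromatic carbon. Within the data shown here, no measured pair differs by this single change, so the size of the step cannot be read from the data and has to be estimated. Among the measured compounds shown here, nothing among the measured values suggests that this swap would bring the number inside the measurable range of this assay. The expected step in this assay is a number no higher from compound 1 to compound 4 (the limit leaves the size open), which is to say none beyond the usual scatter. Compound 4 is therefore expected to give about 100000 nM in this assay, with a likely span from 40000 nM to 300000 nM, and a fair chance that only a limit will again be reported.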

Compound 4, half-maximal inhibitory concentration: > 100000 nM
Compound 4: a limit, no number; the forecaster's own chance of this, stated with the estimate: 70%; the middle value lies on the limit itself.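

Within the data shown here, compound 1 and compound 4 both give only a limit in this assay, so no step between them can be read. The compounds shown leave open whether methoxy in place of methylamino on an aromatic carbon changes the value at all, and by how much, as most of them give no number: the limit of > 100000 nM in this assay, at which 3 of the 4 values shown sit.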